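Hydrazone aryl replacement: from compound 3 to compound 4

The source may hold more compounds than are shown below. What is called first, only, known or untested is meant among the compounds shown, and "the series" means these compounds.

Measured so far in a functional assay on the whole organism (strain Wistar) for inhibition, with Rattus norvegicus as the target, read by paw edema, with a stated time of 1 h, at a dose of 10 mg/kg by the intraperitoneal route; on this read-out higher numbers stand for more inhibition at the one dose given (going by the name of the read-out) and lower numbers for less inhibition:
compound 1, `O=C(N/N=C/c1ccc(Cl)cc1)c1cccnc1Nc1cccc(C(F)(F)F)c1`, gives 67.2%.
compound 2, `O=C(N/N=C/c1cccc(O)c1)c1cccnc1Nc1cccc(C(F)(F)F)c1`, gives 63.8%.
compound 3, `COc1ccc(/C=N/NC(=O)c2cccnc2Nc2cccc(C(F)(F)F)c2)c(OC)c1`, gives 55.7%.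

Compound 3 carries the lowest of the three numbers. Its nearest neighbour is compound 2, with a number 8.1 percentage points lower from compound 2 to compound 3 (within the scatter), and its furthest is compound 1, with a number 11.5 percentage points lower from compound 1 to compound 3 (beyond the scatter). The remaining pair shows a number 3.4 percentage points lower from compound 1 to compound 2 (within the scatter). All three measured steps change the aryl group on the carbon with a double bond to nitrogen, while the rest of the shared core is held constant.

Compound 4, `O=C(N/N=C/c1cccnc1)c1cccnc1Nc1cccc(C(F)(F)F)c1`, is not yet measured. It differs from compound 3 by pyridin-3-yl in place of 2,4-dimethoxyphenyl on a carbon with a double bond to nitrogen. No measured step puts a ring with a hetero atom at this place, so the change has no direct counterpart among the three steps shown; the closest guides are the two steps leading into compound 3, both of which moved the read-out downward by a modest amount or within the scatter. Since compound 3 sits at the bottom of the series and every variation of this aryl group so far has stayed within a narrow band, the step expected in this assay is a number 5.3 percentage points higher from compound 3 to compound 4 (within the scatter), small and upward, not clearly beyond the scatter. The estimate for compound 4 is 61%, with a range from 49% to 73%.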

Compound 4, a percentage reported as inhibition, in the whole organism at one dose (the size of the read-out at that dose, not a potency): 76.1%
Compound 4: the middle estimate sits 15.1 percentage points below what was measured; measured number outside the range, above it.
By their numbers in this assay, from the lowest: compounds 3, 2, 1 and 4 (each within the scatter of the next, the first and the last beyond it).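

In this assay the place on a carbon with a double bond to nitrogen, so far filled only by aromatic rings of carbon, also accepts a six-membered aromatic ring with a hetero atom, and pyridin-3-yl gives a number 20.4 percentage points higher from compound 3 to compound 4 (beyond the scatter) as well as a number 12.3 percentage points higher from compound 2 to compound 4 (beyond the scatter) while the rest of the shared core stays constant. The same replacement gives a number 8.9 percentage points higher from compound 1 to compound 4 (within the scatter) and so does not separate pyridin-3-yl from 4-chlorophenyl, which means the read-out at this place depends on the aryl group more than compounds 1, 2 and 3 alone suggested, with compound 1 and compound 4 forming an upper pair. No measurement at hand explains these steps, and the change of ring, its size and its acceptor count cannot be told apart here.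

A single ring with a hetero atom leaves open whether the effect follows the ring nitrogen or its location, which pyridin-2-yl and pyridin-4-yl would address. Also open, as far as these compounds go, is how this place responds to a non-aromatic group such as piperidinyl, or to a phenyl ring carrying a carboxylic acid or an amine.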